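Swapping the ring on the amide nitrogen again

A few compounds are considered here, and "the series" means these few. Any claim that something is new, unique, unknown or untested is made for them only; others in the source may bear on it.

Measured so far:
compound 1, `CC(C)[C@H](C(=O)Nc1ncns1)c1ccc(Cl)cc1`: 99%
compound 2, `CC(C)[C@H](C(=O)NC1=NC(=O)CS1)c1ccc(Cl)cc1`: 96%

In a functional assay on CHO cells for agonist activity at Free fatty acid receptor 2 (Homo sapiens), read by cAMP accumulation (a higher number here means a larger maximal response, a lower number a smaller maximal response), compound 1 gives 99% and compound 2 gives 96%. Compound 2 holds the lower of the two numbers, but the step of a number 3 percentage points lower from compound 1 to compound 2 (within the scatter) lies within the scatter, so the two compounds cannot be told apart on these data.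

Compound 3, `Cc1csc(NC(=O)[C@H](c2ccc(Cl)cc2)C(C)C)n1`, has not yet been measured. It differs from compound 2 in one place: a group of 6 heavy atoms (4 carbon, 1 nitrogen, 1 sulfur; one five-membered aromatic ring with 2 hetero atoms) in place of a group of 6 heavy atoms (3 carbon, 1 nitrogen, 1 oxygen, 1 sulfur; one five-membered non-aromatic ring with 2 hetero atoms), on an amide-type nitrogen

Going by the values given here, the only measured step that bears on this change is a number 3 percentage points lower from compound 1 to compound 2 (within the scatter), where one five-membered ring was exchanged for another on the same amide-type nitrogen and the maximal response stayed essentially unchanged. Another ring exchange at the same position is therefore expected to leave the response near its present level, with no step beyond the scatter; the expected step is a number 1 percentage points lower from compound 2 to compound 3 (within the scatter). For compound 3 the estimate in this assay is 95%, with a range of 80% to 105%.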

Compound 3, largest response reached (reported as efficacy), in percent of the reference or control that the assay uses: 87%
Compound 3: the middle estimate sits 8 percentage points above what was measured; the range from low to high includes it.
By their numbers in this assay, from the lowest: compounds 3, 2 and 1 (each within the scatter of the next, the first and the last beyond it).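

In this assay, putting 4-methyl-1,3-thiazol-2-yl on the amide-type nitrogen gives a number 9 percentage points lower from compound 2 to compound 3 (within the scatter), and also a number 12 percentage points lower from compound 1 to compound 3 (beyond the scatter). Going by these compounds alone, this is the first step at this position to pass beyond the scatter, so the rings here are not fully interchangeable, although the change is modest and compound 3 still gives 87%. No measurement shown here offers an explanation for this step.

As far as these compounds go, it remains open whether the step belongs to the methyl group or to the ring that carries it, a question that the plain 1,3-thiazol-2-yl group would address. Also open, from the compounds shown here alone, is how a six-membered ring such as pyridin-2-yl, or an open chain such as n-butyl, would behave on this nitrogen.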